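Swapping the Dichlorobenzyl for a Fluorobenzyl

A few compounds are considered here, and "the series" means these few. Any claim that something is new, unique, unknown or untested is made for them only; others in the source may bear on it.

Two compounds share one core. Compound 1 `Nc1cc(N)c2nc(-c3ccccc3)c(Oc3ccc(Cl)c(Cl)c3)nc2c1` and compound 2 `Nc1cc(N)c2nc(-c3ccccc3)c(NCc3ccc(Cl)c(Cl)c3)nc2c1` were both tested in a functional assay on HCT-116 cells (Homo sapiens) for inhibition, read by sulforhodamine B assay, with a stated time of 48 h; a lower number here means that less compound is tolerated, a higher number that more compound is tolerated. For compound 1 the result is only a limit of the assay, < 100000 nM. Going by the values given here, compound 2 gives 50100 nM and is the only compound here with a number rather than a limit, so it is the sole anchor for any comparison. Among the compounds with values here, the one piece of evidence on this set is the limit of < 100000 nM in this assay, at which 1 of the 2 values shown sits. Compound 3 `Nc1cc(N)c2nc(-c3ccccc3)c(NCc3ccc(F)cc3)nc2c1` has not yet been measured. It differs from compound 2 in one place: 4-fluorophenyl in place of 3,4-dichlorophenyl on a saturated chain carbon bound to a nitrogen on an aromatic ring. Within the data shown here, no step between two measured compounds is available to guide this change, so the expectation rests on compound 2 alone. The step from compound 2 to compound 3 is expected to be small, a modest loss at most, a 1.4-fold higher number from compound 2 to compound 3 (0.15 log units; within the scatter), and may well stay within the usual scatter. Compound 3 is expected to give 70000 nM in this assay, with a likely range of 25000 nM to 200000 nM.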

Compound 3, concentration lethal to 50% of the cells: < 100000 nM
Compound 3: a limit, no number; the forecaster's own chance of this, stated with the estimate: 35%; the middle value is on the limit's open side.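

In this assay compound 3 gives < 100000 nM, which is a limit of the assay and not a number. The steps to compound 3 from compound 2 and from compound 1 cannot be read. The compounds shown leave open whether 4-fluorobenzyl and 3,4-dichlorobenzyl differ at all on the shared core.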